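The source may report more compounds than this note shows. Statements on the series, on what has been measured and on what is new or still open speak of the compounds shown alone.

Measured compounds in an assay on isolated protein for inhibition of hexokinase-3 (Rattus norvegicus), with a stated time of 6 h, tested at 10 mM; a lower number here means less inhibition, a higher number more inhibition at the concentration tested (going by the name of the read-out):
Compound 1 `O=C(CI)NCCCCC(=O)NCCCCCCNc1ncnc2c1ncn2[C@@H]1O[C@H](COP(=O)(O)OP(=O)(O)OP(=O)(O)O)[C@@H](O)[C@H]1O` gives 0%.
Compound 2 `CN(CCCN(C)C(=O)CCCCNc1ncnc2c1ncn2[C@@H]1O[C@H](COP(=O)(O)OP(=O)(O)OP(=O)(O)O)[C@@H](O)[C@H]1O)C(=O)CCCCNC(=O)CI` gives 0%.
Compound 3 `O=C(CI)NCCNc1ncnc2c1ncn2[C@@H]1O[C@H](COP(=O)(O)OP(=O)(O)OP(=O)(O)O)[C@@H](O)[C@H]1O` gives 0%.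

Compound 1 stands level with compound 2 and compound 3 at the digits shown; none of the three readings differs from another by more than the usual scatter, and no step between two measured compounds that differ in one place is available. The unmeasured compound 4 `O=C(CI)NCCCC(=O)NCCCCCCNc1ncnc2c1ncn2[C@@H]1O[C@H](COP(=O)(O)OP(=O)(O)OP(=O)(O)O)[C@@H](O)[C@H]1O` is reached from compound 1 by the change (((iodomethyl)carbonyl)amino in place of (((iodomethyl)carbonyl)amino)methyl on a saturated chain carbon, three bonds along the chain from a carbonyl carbon). With every measured compound at the same reading, nothing in the data points to a gain or a loss, so the step is expected to be no change at the digits printed from compound 1 to compound 4 (within the scatter), none beyond the scatter. Compound 4 is therefore estimated at 0% in this assay, with a range from -5% to 10%.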

Compound 4, a percentage reported as inhibition, at one concentration (the size of the read-out at that concentration, not a potency): 0%
Beside the measured number, compound 4's estimate shows no gap at the digits printed; the measured number falls inside the stated range.
By their numbers in this assay, from the lowest: compounds 1, 2, 3 and 4 (each within the scatter of the next).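

In this assay, among the compounds shown here, ((iodomethyl)carbonyl)amino in place of (((iodomethyl)carbonyl)amino)methyl on a saturated chain carbon, three bonds along the chain from a carbonyl carbon, gives no change at the digits printed from compound 1 to compound 4 (within the scatter) and is the first step that can be read at this position. With compound 1 at 0% and compound 4 at 0%, this shorter chain end shows no inhibition at the concentration tested, as the longer one does not. As far as these compounds go, whether an amine or a carboxylic acid in place of the ((iodomethyl)carbonyl)amino group would give any inhibition stays open. No supporting measurement bears on this result.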